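The source may hold more compounds than are shown below. What is called first, only, known or untested is meant among the compounds shown, and "the series" means these compounds.

Measured in an ADME assay on L6 cells (Rattus norvegicus) for cytotoxicity; a higher number here means a weaker inhibitor, a lower number a stronger inhibitor:
Compound 1 `COc1ccc(N2CCN(C(=O)Cn3cnc([N+](=O)[O-])n3)CC2)cc1`: 133000 nM
Compound 2 `O=C(CN1CCN(c2ccc(C(F)(F)F)cc2)CC1)N1CCN(c2ccc(C(F)(F)F)cc2)CC1`: 31700 nM

Of these two, compound 1 has the higher number, 133000 nM, so it is the weaker inhibitor of the pair. Compound 2 stands lower at 31700 nM, and this gap is larger than the usual scatter between repeated measurements.

Compound 3 `N#Cc1ccccc1N1CCN(C(=O)Cn2cnc([N+](=O)[O-])n2)CC1` has not yet been measured. It keeps the core of compound 1 and changes a single group, on an amine nitrogen in a ring: 2-cyanophenyl in place of 4-methoxyphenyl on an amine nitrogen in a ring. Put simply, 2-cyanophenyl takes the place of 4-methoxyphenyl.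

Among the compounds with values here, no two measured compounds differ in just one place, so the data do not show what a swap like this does. Compound 2 differs from compound 1 in more than one place and offers little guidance. The best starting point is therefore compound 1 itself, at 133000 nM, and no step beyond the scatter is expected in this assay, in either direction. The expected change is a 1.1-fold lower number from compound 1 to compound 3 (0.04 log units; within the scatter). For compound 3 the estimated value is 120000 nM, with an expected range of 45000 nM to 320000 nM.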

Compound 3, half-maximal inhibitory concentration: 213000 nM
For compound 3 the middle estimate is 1.8-fold (0.25 log units) below the measured one, and the stated range covers the measured number.
By their numbers in this assay, from the lowest: compound 2; then compounds 1 and 3 (each within the scatter of the next).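

In this assay, within the data shown here, putting 2-cyanophenyl in place of 4-methoxyphenyl on an amine nitrogen in a ring gives a 1.6-fold higher number from compound 1 to compound 3 (0.20 log units; within the scatter) and is the first comparison here in which only one group changes. This position therefore accepts this exchange without a change that can be told apart from ordinary repeat variation in this assay, even though a methoxy group leaves and a nitrile enters, and the numbers in the two names show that the attachment point on the aromatic ring differs as well. Nothing measured here explains why the two compounds give such similar results.

This single step cannot separate the effect of changing the group from the effect of changing its attachment point, and 4-cyanophenyl or 2-methoxyphenyl would be needed to pull those two changes apart. From the compounds shown here alone, it also remains open whether a different kind of group at this position, such as a phenyl ring carrying an amine or a carboxylic acid, or a cyclohexyl ring in place of the aromatic ring, would shift the number beyond that variation.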